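A chloro group added to compound 3

The source may hold more compounds than are shown below. What is called first, only, known or untested is meant among the compounds shown, and "the series" means these compounds.

- compound 1 `Cc1ccc(NS(=O)(=O)c2cccc(CCCCCCNC(=O)/C=C/c3cccnc3)c2)cc1`: 1.97 nM
- compound 2 `CCc1ccc(NS(=O)(=O)c2cccc(CCCCCCNC(=O)/C=C/c3cccnc3)c2)cc1`: 3.64 nM
- compound 3 `O=C(/C=C/c1cccnc1)NCCCCCCc1cccc(S(=O)(=O)Nc2ccc(F)cc2)c1`: 0.91 nM

In a functional assay on MCF7 cells (Homo sapiens) for inhibition, read by CCK-8 assay, with a stated time of 72 h (on this read-out lower numbers stand for stronger inhibition and higher numbers for weaker inhibition), compound 3 gives 0.91 nM, the lowest of the three numbers. Compound 4 `O=C(/C=C/c1cccnc1)NCCCCCCc1cccc(S(=O)(=O)Nc2ccc(F)c(Cl)c2)c1` differs from compound 3 by chloro in place of hydrogen on an aromatic carbon, which turns 4-fluorophenyl into 3-chloro-4-fluorophenyl.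

The nearest evidence comes from changes at the existing fluoro position. Fluoro in place of methyl gave a 2.2-fold lower number from compound 1 to compound 3 (0.34 log units; beyond the scatter), and fluoro in place of ethyl gave a 4.0-fold lower number from compound 2 to compound 3 (0.60 log units; beyond the scatter), both modest. Methyl added to the chain gave a 1.8-fold higher number from compound 1 to compound 2 (0.27 log units; within the scatter), which lies within the scatter. Among the measured compounds shown here, no measured compound carries a second group on this aromatic ring, so these steps offer only indirect guidance. Given their small size, no step beyond the scatter is expected, with a slight lean towards a higher number.

The expected step is a 1.6-fold higher number from compound 3 to compound 4 (0.22 log units; within the scatter). For compound 4 the estimated value is 1.5 nM, with an expected range of 0.5 nM to 5 nM.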

Compound 4, half-maximal inhibitory concentration: 6.3 nM
The estimate for compound 4 lay 4.2-fold (0.62 log units) below the measured number; measured number outside the range, above it.
By their numbers in this assay, from the lowest: compound 3; then compounds 1, 2 and 4 (each within the scatter of the next, the first and the last beyond it).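

In this assay, chloro in place of hydrogen on the 4-fluorophenyl ring, ortho to the fluoro group, gives a 6.9-fold higher number from compound 3 to compound 4 (0.84 log units; beyond the scatter) and is the only step shown that adds a second group to this ring rather than changing the group already there. The 3-chloro-4-fluorophenyl group gives a 3.2-fold higher number from compound 1 to compound 4 (0.50 log units; beyond the scatter) when set against 4-methylphenyl, and a 1.7-fold higher number from compound 2 to compound 4 (0.24 log units; within the scatter) when set against 4-ethylphenyl, so the lead that compound 3 held over compounds 1 and 2 does not survive the added chloro. Nothing in the data shown accounts for this step.

Still open, going by these compounds, is whether a bromo or methoxy group at this place would give a step of like size. Also open, on these data alone, is whether chloro would have the same effect on a ring without the fluoro group.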